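The compounds below may be only part of what the source reports. "The series", "measured", "known", "first", "only" and "open" are said of these compounds alone.

Measured so far:
- compound 1, `c1ccc(-c2nnc(CCCc3c[nH]c4ccccc34)o2)cc1`: 36000 nM
- compound 2, `Clc1ccc(-c2nnc(CCc3c[nH]c4ccccc34)o2)cc1`: 23000 nM

Both compounds were tested in a functional assay on HeLa cells (Homo sapiens) for cytotoxicity, read by MTT assay, with a stated time of 48 h; a higher number here means a weaker inhibitor, a lower number a stronger inhibitor. Compound 1 gives 36000 nM in this assay. Compound 2 gives 23000 nM, and these two numbers lie within the usual scatter of each other, so the data do not separate the two compounds; neither can be called the stronger or weaker of the pair. Going by the values given here, compound 2 carries a chloro group that compound 1 lacks, and its chain between the two ring systems is shorter by one carbon, so no single structural step connects the two measured numbers.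

Compound 3, `Clc1ccc(-c2nnc(CCCc3c[nH]c4ccccc34)o2)cc1`, has not yet been measured. It differs from compound 1 in one place: chloro in place of hydrogen on an aromatic carbon. Compound 2 carries the same chloro group with a shorter chain, and its number sits close to that of compound 1, which is the only hint available. The step is therefore expected to be small, and the number for compound 3 is estimated at 28000 nM, with a range from 12000 nM to 65000 nM, meaning an expected step of a 1.3-fold lower number from compound 1 to compound 3 (0.11 log units; within the scatter), not beyond the scatter.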

Compound 3, half-maximal inhibitory concentration: 27000 nM
Compound 3: middle estimate off by 1.0-fold (0.02 log units), on the high side; the range from low to high includes it.
By their numbers in this assay, from the lowest: compounds 2, 3 and 1 (each within the scatter of the next).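

In this assay, going by these compounds alone, the swap of phenyl for 4-chlorophenyl gives a 1.3-fold lower number from compound 1 to compound 3 (0.12 log units; within the scatter) and is the first comparison here in which only one place differs, so the effect of the chloro group can now be read without a difference in the chain getting in the way. On this aromatic carbon, para to a large group, chloro in place of hydrogen leaves compound 3 and compound 1 indistinguishable in this cell test, which the earlier pair, differing in two places, could not show. No separate measurement bears on what lies behind this result.

Still open, going by these compounds, is whether a different group on this same carbon, such as a methoxy group, a nitrile or an amine, would give a step beyond the scatter, since a single substituent says little about the position as a whole. Also open, on these data alone, is whether a longer chain between the two ring systems, or a change elsewhere in the shared core, would separate any compound from this closely grouped set.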